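A 4-hydroxyphenyl in place of 2-methylphenyl

The compounds below may be only part of what the source reports. "The series", "measured", "known", "first", "only" and "open" are said of these compounds alone.

compound 1 `Cc1ccccc1OS(=O)(=O)c1cccc(NC(=O)NCCCCl)c1`: 29000 nM
compound 2 `CCNC(=O)Nc1cccc(S(=O)(=O)Oc2ccccc2C)c1`: 51000 nM

Both compounds were tested in a functional assay on M21 cells (Homo sapiens) for cytotoxicity, read by sulforhodamine B assay, with a stated time of 48 h; a lower number here means a stronger inhibitor, a higher number a weaker inhibitor. Compound 2 gives 51000 nM and compound 1 gives 29000 nM, so on these numbers the two cannot be told apart. Going by the values given here, the one measured step is a 1.8-fold higher number from compound 1 to compound 2 (0.25 log units; within the scatter). It lies on a saturated chain carbon, elsewhere in the molecule, and it stays within the scatter.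

The next compound is compound 3 `CCNC(=O)Nc1cccc(S(=O)(=O)Oc2ccc(O)cc2)c1`. It differs from compound 2 at a single place, with 4-hydroxyphenyl in place of 2-methylphenyl on an oxygen whose other neighbour is the sulfonyl sulfur (4-hydroxyphenyl in place of 2-methylphenyl on an oxygen). Among the compounds with values here, no measured pair varies this group, so the measured step bears on the change only weakly, and its direction remains unknown. With compound 2 at 51000 nM as the only close reference, no step beyond the scatter is expected in this assay, although the uncertainty is wide. The expected change is a 1.1-fold higher number from compound 2 to compound 3 (0.03 log units; within the scatter). Compound 3 is estimated at 55000 nM, with an expected range from 20000 nM to 150000 nM.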

Compound 3, half-maximal inhibitory concentration: 42000 nM
For compound 3 the middle estimate is 1.3-fold (0.12 log units) above the measured one; the measured number falls inside the stated range.
By their numbers in this assay, from the lowest: compounds 1, 3 and 2 (each within the scatter of the next).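

In this assay, going by these compounds alone, replacing 2-methylphenyl with 4-hydroxyphenyl on the oxygen whose other neighbour is the sulfonyl sulfur gives a 1.2-fold lower number from compound 2 to compound 3 (0.08 log units; within the scatter), and this is the first measured change at this position. The two groups have the same count of 7 heavy atoms, but 4-hydroxyphenyl brings 1 hydrogen-bond donor and 1 hydrogen-bond acceptor where 2-methylphenyl has 0 of each, and this exchange does not separate compound 2 from compound 3 in this assay. Like the earlier change on the saturated chain, it stays within the scatter, and no measured property is available to account for the result.

Within the data shown here, the three compounds show only that these two groups cannot be told apart at this place, so it remains open whether a carboxylic acid, an amine or a larger ring system on that oxygen would move the number beyond the scatter. It is also open whether 4-hydroxyphenyl would give a similar result alongside the chloromethyl group of compound 1, or on a longer chain, since no compound shown carries such a combination.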